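Working notes: chloro in place of hydrogen on compound 3

The source may hold more compounds than are shown below. What is called first, only, known or untested is meant among the compounds shown, and "the series" means these compounds.

In a functional assay on K562 cells (Homo sapiens) for antiproliferative activity, read by MTT assay, with a stated time of 48 h (a lower number here means a stronger inhibitor, a higher number a weaker inhibitor), compound 1 `CCN(CC)CCn1c(N)c(-c2nc3ccccc3[nH]2)c2nc(C#N)c(C#N)nc21` gives 2490 nM, compound 2 `CN1CCN(CCn2c(N)c(-c3nc4ccccc4[nH]3)c3nc(C#N)c(C#N)nc32)CC1` gives 6550 nM and compound 3 `CN(C)CCCn1c(N)c(-c2nc3ccccc3[nH]2)c2nc(C#N)c(C#N)nc21` gives 1730 nM. Compound 3 stands level with compound 1, since a 1.4-fold lower number from compound 1 to compound 3 (0.16 log units; within the scatter) lies within the scatter. Compound 3 stands clear of compound 2, as shown by a 3.8-fold lower number from compound 2 to compound 3 (0.58 log units; beyond the scatter), and a 2.6-fold higher number from compound 1 to compound 2 (0.42 log units; beyond the scatter) separates the other pair.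

Compound 4 `CN(C)CCCn1c(N)c(-c2nc3cc(Cl)ccc3[nH]2)c2nc(C#N)c(C#N)nc21` differs from compound 3 in one place: chloro in place of hydrogen on an aromatic carbon. Chloro replaces hydrogen on an aromatic carbon, turning 1H-benzimidazol-2-yl into 5-chloro-1H-benzimidazol-2-yl. Going by the values given here, no measured step touches this site, because all three fall on the saturated chain. They offer only a rough scale, and the largest is a 3.8-fold lower number from compound 2 to compound 3 (0.58 log units; beyond the scatter). A shift of no more than that size is expected, with its direction unsettled by the data and only a slight lean towards a lower number. The expected change is a 1.4-fold lower number from compound 3 to compound 4 (0.16 log units; within the scatter). Compound 4 is estimated at 1200 nM, with an expected range of 450 nM to 3200 nM.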

Compound 4, half-maximal inhibitory concentration: 10700 nM
Compound 4: the middle estimate sits 8.9-fold (0.95 log units) below what was measured; measured number above the stated range.
By their numbers in this assay, from the lowest: compounds 3 and 1 (each within the scatter of the next); then compounds 2 and 4 (each within the scatter of the next).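

In this assay the change from 1H-benzimidazol-2-yl to 5-chloro-1H-benzimidazol-2-yl gives a 6.2-fold higher number from compound 3 to compound 4 (0.79 log units; beyond the scatter) and so moves towards a weaker inhibitor. Going by these compounds alone, the earlier steps all lay on the saturated chain, so this is the first reading from the aromatic ring, and it shows that this aromatic carbon does not tolerate chloro without a loss beyond the scatter. Nothing at hand accounts for this shift.

Going by these compounds, whether fluoro, methyl or methoxy on this same carbon would follow chloro, or whether chloro on another carbon of the six-membered ring would behave alike, stays open. Also open, on these data alone, is whether 5-chloro-1H-benzimidazol-2-yl brings the same loss alongside the diethylamino chain of compound 1 or the 4-methylpiperazin-1-yl chain of compound 2.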